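This account rests on a few compounds, and the source may have more. Where it says the series, first, only, none or still open, it means among the compounds named here.

Measured so far in an ADME assay on microsomes from liver (Rattus norvegicus) for metabolic stability, using NADPH, with a stated time of 10 min; a lower number here means that less of the compound is left, a higher number that more of the compound is left:

compound 1, `CCCCc1nc(=O)c(S(=O)(=O)c2ccc(-c3ccnc(NC(=O)C4CC4)c3)cc2)c(O)n1-c1c(OC)cccc1OC`, gives 72%
compound 2, `CCCCc1nc(=O)c(S(=O)(=O)c2ccc(-c3cccnc3)cc2)c(O)n1-c1c(OC)cccc1OC`, gives 3%
compound 3, `CCCCc1nc(=O)c(S(=O)(=O)c2ccc(-n3ccccc3=O)cc2)c(O)n1-c1c(OC)cccc1OC`, gives 83%

Compound 3 stands highest of the three in this assay: its nearest neighbour is compound 1, with a number 11 percentage points higher from compound 1 to compound 3 (beyond the scatter), and the furthest is compound 2, with a number 80 percentage points higher from compound 2 to compound 3 (beyond the scatter). All three share one core and differ only in the group attached to the aromatic carbon of the sulfonyl-bearing ring.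

Compound 4, `CCCCc1nc(=O)c(S(=O)(=O)c2ccc(-n3cc(Cl)ccc3=O)cc2)c(O)n1-c1c(OC)cccc1OC`, is the next step from compound 3. The change is chloro in place of hydrogen on an aromatic carbon of the six-membered ring with one nitrogen, two atoms from the ring nitrogen.

Among the measured compounds shown here, none of the measured steps is of the same kind. Each of them swaps out the whole ring group, as in a number 69 percentage points lower from compound 1 to compound 2 (beyond the scatter) and a number 11 percentage points higher from compound 1 to compound 3 (beyond the scatter), and those steps are large to modest. Adding a single chlorine while keeping the ring in place is a smaller change, and nothing measured here shows how such a substitution shifts the read-out in this assay. The expectation is therefore a step of a number 8 percentage points lower from compound 3 to compound 4 (within the scatter), likely within the scatter, with a slight lean downward.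

Compound 4 is estimated at 75% in this assay, within 50% to 92%.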

Compound 4, percent of the compound remaining: 74%
For compound 4 the middle estimate is 1 percentage points above the measured one; the measured number falls inside the stated range.
By their numbers in this assay, from the lowest: compound 2; then compounds 1, 4 and 3 (each within the scatter of the next, the first and the last beyond it).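

In this assay, chloro in place of hydrogen on an aromatic carbon of the six-membered ring, two atoms from the ring nitrogen, gives a number 9 percentage points lower from compound 3 to compound 4 (within the scatter) and so cannot be told apart from repeat-to-repeat variation at this position. The chlorinated group also keeps the wide gap to the pyridin-3-yl group of compound 2 (a number 71 percentage points higher from compound 2 to compound 4 (beyond the scatter)) and reads level with the bigger group of compound 1 (a number 2 percentage points higher from compound 1 to compound 4 (within the scatter)), which shows that this ring can carry a chlorine at this carbon and still leave much of the compound remaining. Nothing measured here speaks to the reason for this result.

The compounds shown cover only one small group at one carbon of this ring, so it stays open whether an amine or a carboxylic acid at the same place would also leave the read-out where it is, and whether chloro at another carbon of the ring would do the same. On these data alone, it also stays open whether chloro on the pyridin-3-yl ring of compound 2 would move that compound's low read-out at all.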